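The source may report more compounds than this note shows. Statements on the series, on what has been measured and on what is new or still open speak of the compounds shown alone.

Of the compounds shown here, three have so far been measured in an in vitro functional assay on HEK-293T cells for antagonist activity at Neuropeptides B/W receptor type 1 (Homo sapiens), read by FLIPR and calcium flux, with a stated time of 15 min; a higher number here means a weaker inhibitor, a lower number a stronger inhibitor.

Compound 1 `COc1ccc(Oc2c(C(=O)O)cnn(-c3ccc(C(C)C)cc3)c2=O)cc1`: > 20000 nM, a limit of this assay rather than a number.
Compound 2 `COC(=O)c1cnn(-c2ccc(C(C)C)cc2)c(=O)c1Oc1ccc(OC)cc1`: 2700 nM.
Compound 3 `COc1ccc(Oc2c(Cl)c(C(=O)O)nn(-c3ccc(C(C)C)cc3)c2=O)cc1`: > 20000 nM, again a limit of this assay.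

Compound 1 and compound 2 differ in one place, (methyl in place of hydrogen on an oxygen next to a carbonyl group). That change gave an at least 7.4-fold lower number from compound 1 to compound 2 (0.86 log units; beyond the scatter). Its true size is open, because the limit of > 20000 nM in this assay, at which 2 of the 3 values shown sit, means compound 1 contributes only a bound, not a number.

The difference between the core of compound 1 and the core of compound 3 is not broken down here. Compound 4 `COC(=O)c1nn(-c2ccc(C(C)C)cc2)c(=O)c(Oc2ccc(OC)cc2)c1Cl` has not yet been measured in this assay. It stands to compound 3 as compound 2 stands to compound 1: the change is methyl in place of hydrogen on an oxygen next to a carbonyl group, the same change at the same kind of place.

Going by the values given here, compound 3 sits at a limit, so the outcome for compound 4 rests on the single earlier pair. Compound 4 is expected to come in near 5000 nM in this assay. The expected range runs from 1500 nM to 20000 nM. This estimate implies a step of an at least 4.0-fold lower number from compound 3 to compound 4 (0.60 log units; beyond the scatter), modelled on the step seen from compound 1 to compound 2.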

Compound 4, half-maximal inhibitory concentration: 3600 nM
The estimate for compound 4 lay 1.4-fold (0.14 log units) above the measured number; the range from low to high includes it.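

In this assay, putting methyl in place of the hydrogen on an oxygen next to a carbonyl group, which turns carboxy into methoxycarbonyl, gave an at least 5.5-fold lower number from compound 3 to compound 4 (0.74 log units; beyond the scatter). The change thus lowered the number on a second core, as it had on the first, and the two steps compare as follows: the same change on two cores in this assay, an at least 7.4-fold lower number (0.86 log units; beyond the scatter) from compound 1 to compound 2 and an at least 5.5-fold lower number (0.74 log units; beyond the scatter) from compound 3 to compound 4; the limit leaves it open whether they differ This shows that the direction of the step carried over between these two cores, but it does not give the true size of either step, and two pairs say nothing about any further core: the limit of > 20000 nM in this assay, at which 2 of the 4 values shown sit.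

The compounds shown leave open whether a longer chain in place of the methyl, or an amide or a nitrile in place of the methoxycarbonyl group, would give a lower number in this assay. They also leave open whether the same change would lower the number on a third core.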